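Bromo to methoxy on the acetyl compound

This account rests on a few compounds, and the source may have more. Where it says the series, first, only, none or still open, it means among the compounds named here.

Values in a functional assay on PC-3 cells (Homo sapiens) for cytotoxicity, read by MTT assay, with a stated time of 48 h; a lower number here means a stronger inhibitor, a higher number a weaker inhibitor:
- compound 1 `COc1ccc(-c2cn(C(=O)Nc3cc(OC)c(OC)c(OC)c3)c(=O)n2-c2cc(OC)c(OC)c(OC)c2)cc1`: 49700 nM
- compound 2 `COc1ccc(-c2cn(C(=O)Nc3cc(OC)c(OC)c(OC)c3)c(=O)n2-c2cc(OC)c(OC)c(OC)c2)cc1OC`: > 50000 nM (a limit)
- compound 3 `COc1cc(-n2c(-c3ccc(Br)cc3)cn(C(C)=O)c2=O)cc(OC)c1OC`: 3100 nM

Compound 3 has the lowest number, and its gap to compound 1 lies clearly beyond the scatter. Compound 1 gives 49700 nM. The entry for compound 2 is only a limit, as noted in the limit of > 50000 nM in this assay, at which 1 of the 3 values shown sits.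

Compound 4 `COc1ccc(-c2cn(C(C)=O)c(=O)n2-c2cc(OC)c(OC)c(OC)c2)cc1` differs from compound 3 by methoxy in place of bromo on an aromatic carbon: 4-bromophenyl becomes 4-methoxyphenyl. Within the data shown here, the one measured step, a number no lower from compound 1 to compound 2 (the limit leaves the size open), also introduces methoxy, but in place of hydrogen, and its size stays open. It gives little guidance, so no change beyond the scatter is expected in this assay. The expected step is a 1.3-fold higher number from compound 3 to compound 4 (0.11 log units; within the scatter). For compound 4 the estimated value is 4000 nM, with an expected range of 1200 nM to 15000 nM.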

Compound 4, half-maximal inhibitory concentration: 19700 nM
For compound 4 the middle estimate is 4.9-fold (0.69 log units) below the measured one; the whole stated range lies below it.
By their numbers in this assay, from the lowest: compound 3; then compound 4; then compound 1. At a limit, above all of these: compound 2.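

In this assay, methoxy in place of bromo gives a 6.4-fold higher number from compound 3 to compound 4 (0.80 log units; beyond the scatter), a step of readable size at this position, para to a large group. Substitution here therefore matters on the acetyl compounds, which the earlier methoxy step, left open by its limit, could not show. The data shown offer no measured property that accounts for this step.

Going by these compounds, how an amine or a chloro group at this position would compare with compound 3 stays open. So does whether the bromo to methoxy change would carry over to the core of compound 1.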